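The source may report more compounds than this note shows. Statements on the series, on what has been measured and on what is new or still open speak of the compounds shown alone.

In an ADME assay on MRC5 cells (Homo sapiens) for inhibition, with a stated time of 72 h (on this read-out higher numbers stand for an effect only at larger amounts of compound and lower numbers for an effect already at smaller amounts), compound 2 `CO[C@H]1CC[C@H](NC(=O)c2n[nH]cc2NC(=O)c2ccccc2)CC1` gives 800 nM, the lowest of three numbers, while compound 1 `CO[C@H]1CC[C@H](NC(=O)c2n[nH]cc2NC(=O)c2ccc(OC(F)F)cc2)CC1` gives 2500 nM and compound 3 `CO[C@H]1CC[C@H](NC(=O)c2n[nH]cc2NC(=O)c2ccc(N3CCN(C)CC3)cc2)CC1` gives 20000 nM. Compound 4 `CO[C@H]1CC[C@H](NC(=O)c2n[nH]cc2NC(=O)c2cc(F)cc(F)c2)CC1` differs from compound 2 by 3,5-difluorophenyl in place of phenyl on a carbonyl carbon. Within the data shown here, two measured steps bear on this change: a 3.1-fold lower number from compound 1 to compound 2 (0.49 log units; beyond the scatter), with hydrogen in place of difluoromethoxy, and a 25-fold higher number from compound 2 to compound 3 (1.40 log units; beyond the scatter), with 4-methylpiperazin-1-yl in place of hydrogen. Neither step involves the fluorine substitution itself, so they suggest direction more than size. A small step toward a higher number is therefore expected, probably not beyond the scatter. The estimated change is a 1.6-fold higher number from compound 2 to compound 4 (0.21 log units; within the scatter). For compound 4, the expected value is 1300 nM, with an estimated range of 450 nM to 4000 nM.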

Compound 4, half-maximal effective concentration: 600 nM
For compound 4 the middle estimate is 2.2-fold (0.34 log units) above the measured one; low and high end bracket the measured number.
By their numbers in this assay, from the lowest: compounds 4 and 2 (each within the scatter of the next); then compound 1; then compound 3.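

In this assay, a 1.3-fold lower number from compound 2 to compound 4 (0.12 log units; within the scatter) shows that this change on the carbonyl carbon, unlike the difluoromethoxy and 4-methylpiperazin-1-yl changes on the ring, leaves the number within the scatter. So a substituted ring here need not move the number beyond the scatter, as those two changes did. Nothing available explains this result. The compounds shown leave open whether a single fluorine would also stay within the scatter. They also leave open whether a smaller amine or a carboxylic acid on this ring would move the number as far as the 4-methylpiperazin-1-yl group does.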